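Aryl amide variation in a bile acid receptor series

The source may hold more compounds than are shown below. What is called first, only, known or untested is meant among the compounds shown, and "the series" means these compounds.

Compound 3 `O=C(O)c1cnc(N2C(=O)CCc3cc(OCc4c(-c5c(Cl)cccc5Cl)noc4C4CC4)ccc32)c(Cl)c1` gives, in an assay on isolated protein for agonist activity at Bile acid receptor (Homo sapiens), read by AlphaScreen, with a stated time of 1 h (a lower number here means a smaller maximal response, a higher number a larger maximal response), a limit of > 100% rather than a number. Compound 1 `Cn1cc(C(=O)O)c2ccc(N3C(=O)CCc4cc(OCc5c(-c6c(Cl)cccc6Cl)noc5C5CC5)ccc43)cc21` likewise reaches only the limit > 100% in this assay. Compound 2 `O=C1CCc2cc(OCc3c(-c4c(Cl)cccc4Cl)noc3C3CC3)ccc2N1c1ncc(O)cc1F` also sits at a limit, > 100%. The step that the two limits leave unreadable from compound 2 to compound 3 cannot be sized, because the limit of > 100% in this assay, at which 3 of the 3 values shown sit, puts all three values shown at one limit. Compound 4 `O=C(O)c1ccc(N2C(=O)CCc3cc(OCc4c(-c5c(Cl)cccc5Cl)noc4C4CC4)ccc32)cc1O` differs from compound 3 by 4-carboxy-3-hydroxyphenyl in place of 5-carboxy-3-chloropyridin-2-yl on an amide-type nitrogen in a ring. Going by the values given here, no measured step bears on this change with a readable size; all three measured compounds sit at the same limit. Compound 4 is therefore expected to reach the limit again, with the step that the limit leaves unreadable from compound 3 to compound 4 estimated to lie within the scatter. For compound 4 the estimate is 105%, ranging from 90% to 125%.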

Compound 4, largest response reached (Emax), in percent of the reference or control that the assay uses: > 100%
Compound 4: a limit, no number; the forecaster's own chance of this, stated with the estimate: 80%; the middle value lies beyond the limit too.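

Going by these compounds alone, no step from compound 3 to compound 4 or from compound 2 to compound 4 can be read in this assay because the values share one limit: the limit of > 100% in this assay, at which 4 of the 4 values shown sit.
From the compounds shown here alone, how far the largest responses of compound 1, compound 2, compound 3 and compound 4 lie apart remains open.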